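The source may report more compounds than this note shows. Statements on the series, on what has been measured and on what is new or still open speak of the compounds shown alone.

Measured compounds:

Compound 1, `CCCn1c(=O)n(CCC(=O)O)c(=O)c2[nH]cnc21`: in an assay on Cerebral cortex for binding affinity to adenosine receptor A1 (Cavia porcellus), read by radioligand binding (a higher number here means a weaker inhibitor, a lower number a stronger inhibitor), compound 1 gives > 200000 nM, which is a limit of the assay rather than a number.
Compound 2, `CCCn1c(=O)n(CCOCC)c(=O)c2[nH]cnc21`: in this assay compound 2 gives 1900 nM.
Compound 3, `CCCn1c(=O)n(CC(C)=O)c(=O)c2[nH]cnc21`: in this assay compound 3 gives 11400 nM.

Of the two numbers in hand, compound 3 stands highest; the nearest is compound 2, separated by a 6.0-fold higher number from compound 2 to compound 3 (0.78 log units; beyond the scatter). Compound 1 sits only at the limit of > 200000 nM in this assay, at which 1 of the 3 values shown sits.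

Compound 4 is `CCCn1c(=O)n(CCCCC(C)=O)c(=O)c2[nH]cnc21`. Its change from compound 3 is 3-acetylpropyl in place of acetyl on a saturated chain carbon bound to an aromatic nitrogen. Within the data shown here, two measured steps concern this same position. The step of an at least 17-fold lower number from compound 1 to compound 3 (1.24 log units; beyond the scatter) was large, while a 6.0-fold higher number from compound 2 to compound 3 (0.78 log units; beyond the scatter) was modest; together they show that what is carried on this chain carbon shifts the number strongly, and the longer chain of compound 2 went with the lower of the two numbers. A modest lowering is therefore expected for compound 4 in this assay, amounting to a 2.9-fold lower number from compound 3 to compound 4 (0.45 log units; beyond the scatter). The estimate for compound 4 is 4000 nM, with a range from 1000 nM to 15000 nM.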

Compound 4, inhibition constant: 23100 nM
The estimate for compound 4 lay 5.8-fold (0.76 log units) below the measured number; the whole stated range lies below it.
By their numbers in this assay, from the lowest: compound 2; then compound 3; then compound 4. At a limit, above all of these: compound 1.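

Lengthening the chain that carries the acetyl group does not lower the number in this assay; instead the result is a 2.0-fold higher number from compound 3 to compound 4 (0.31 log units; beyond the scatter). Chain length alone therefore does not set the number at this position, as the group at the chain end also counts: with an ethoxy end in place of the acetyl end, the comparison reads a 12-fold higher number from compound 2 to compound 4 (1.08 log units; beyond the scatter). With a limit on the carboxy side, an at least 8.6-fold lower number from compound 1 to compound 4 (0.93 log units; beyond the scatter) gives a minimum and not a size: the limit of > 200000 nM in this assay, at which 1 of the 4 values shown sits.

The compounds shown leave open whether a chain ending in an amine or a hydroxyl group would track the ethoxy or the acetyl compounds. They also leave open whether an ethoxy end on a longer chain would keep the lower number of compound 2.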